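Opening the aminocyclopentyl ring of compound 3

The compounds below may be only part of what the source reports. "The series", "measured", "known", "first", "only" and "open" are said of these compounds alone.

Measured compounds:
Compound 1, `CC(C)C[C@H](N)CN(C(=O)[C@@H]1C[C@H]1c1ccccc1)c1ccc(-c2ccccc2)cc1`, gives 880 nM in a functional assay for agonist activity at G protein-coupled receptor 88 (Homo sapiens), read by HTRF and cAMP accumulation; a higher number here means that more compound is needed for the effect, a lower number that less compound is needed.
Compound 2, `CC[C@H](C)[C@H](N)CN(C(=O)[C@@H]1C[C@H]1c1ccccc1)c1ccc(-c2ccccc2)cc1`, gives 230 nM; 800 nM (2 entries) in this assay.
Compound 3, `NC1(CN(C(=O)[C@@H]2C[C@H]2c2ccccc2)c2ccc(-c3ccccc3)cc2)CCCC1`, gives 0.57 nM in this assay.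

Among the single numbers shown, compound 3 stands lowest; its nearest neighbour is compound 1, and the step of a 1500-fold lower number from compound 1 to compound 3 (3.19 log units; beyond the scatter) is large. Compound 2 has several entries, (the several entries of compound 2 in this assay, 230 nM; 800 nM (2 entries)), which spread but do not reach the level of compound 3.

Compound 4, `CCC(C)CNCCN(C(=O)[C@@H]1C[C@H]1c1ccccc1)c1ccc(-c2ccccc2)cc1`, has not yet been measured. The change from compound 3 to compound 4 is ((2-methylbutyl)amino)methyl in place of 1-aminocyclopentyl on a saturated chain carbon bound to an amide-type nitrogen. As in compound 1 and compound 2, compound 4 carries an open chain rather than the five-membered ring of compound 3, and the basic nitrogen here sits one bond further from the amide-type nitrogen than in any measured compound. Within the data shown here, the only step that bears on this is a 1500-fold lower number from compound 1 to compound 3 (3.19 log units; beyond the scatter), which shows how much is lost when the cyclopentyl amine is traded for an open chain. A large rise in the number is therefore expected for compound 4, with the step estimated at a 700-fold higher number from compound 3 to compound 4 (2.85 log units; beyond the scatter). Compound 4 is expected to give about 400 nM, plausibly between 60 nM and 3000 nM.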

Compound 4, half-maximal effective concentration: 4.7 nM
Beside the measured number, compound 4's estimate is 85-fold (1.93 log units) above it; measured number below the stated range.
By their numbers in this assay, from the lowest: compound 3; then compound 4; then compound 1.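

The open chain at this place on a saturated chain carbon bound to an amide-type nitrogen does not by itself carry the large loss seen earlier: in this assay, the step of a 1500-fold lower number from compound 1 to compound 3 (3.19 log units; beyond the scatter) had set an open chain far from the 1-aminocyclopentyl group, yet ((2-methylbutyl)amino)methyl gives only an 8.2-fold higher number from compound 3 to compound 4 (0.92 log units; beyond the scatter), a modest step that still leaves compound 3 with the lower number. Against the other open chain, the same group gives a 190-fold lower number from compound 1 to compound 4 (2.27 log units; beyond the scatter), so the two open chains of compound 1 and compound 4 are far apart and the ring is not what decides the level at this position. None of the information at hand gives a cause for either step.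

The compounds shown do not separate the loss of the ring from the other differences between the 1-aminocyclopentyl and ((2-methylbutyl)amino)methyl groups, so the modest step from the one to the other cannot be assigned to either. Going by these compounds, it also stays open how a 1-aminocyclohexyl group, a longer chain on the amine or a tertiary amine would fare at this place.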